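A few compounds are considered here, and "the series" means these few. Any claim that something is new, unique, unknown or untested is made for them only; others in the source may bear on it.

Measured in an ADME assay on microsomes from liver (Mus musculus) for metabolic stability; on this read-out lower numbers stand for a shorter-lived compound and higher numbers for a longer-lived compound:
compound 1 `CCC(CC)(c1nnc[nH]1)c1ccc(-c2ccc3cc(F)cc(F)c3c2)[nH]c1=O` gives 1.09 h
compound 2 `CC(C)C(Nc1nnc[nH]1)c1ccc(-c2ccc3cccc(F)c3c2)[nH]c1=O` gives 2.42 h
compound 3 `Cc1nc(C(c2ccc(-c3ccc4cccc(F)c4c3)[nH]c2=O)C(C)C)[nH]c1C` gives 0.0817 h

Compound 3 stands lowest of the three numbers in this assay; its nearest neighbour is compound 1 and its furthest is compound 2, both gaps beyond the scatter. Among the compounds with values here, the only measured single-point step, a 30-fold lower number from compound 2 to compound 3 (1.47 log units; beyond the scatter), is the one that bears on the next compound, and it was large. Compound 4 `CC(C)C(CC(N)=O)c1ccc(-c2ccc3cccc(F)c3c2)[nH]c1=O` differs from compound 3 by carbamoylmethyl in place of 4,5-dimethyl-1H-imidazol-2-yl on a saturated chain carbon bound to an aromatic carbon and a saturated chain carbon. The 4,5-dimethyl-1H-imidazol-2-yl that leaves is the same group that entered in the step from compound 2 to compound 3; carbamoylmethyl has not been measured anywhere in this series, so the entering group carries no data of its own. The expectation is therefore a step upward in this assay for compound 4, roughly undoing the earlier change, of a size like a 12-fold higher number from compound 3 to compound 4 (1.09 log units; beyond the scatter), with wide uncertainty. Compound 4 is estimated at 1 h in this assay, with a range from 0.3 h to 3 h.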

Compound 4, half-life: < 0.0667 h
Compound 4 ended at the assay's limit; the forecaster's own chance of this, stated with the estimate: 5%; middle value at least 14-fold (1.17 log units) from the limit.
By their numbers in this assay, from the lowest: compound 3; then compound 1; then compound 2. At a limit, below all of these: compound 4.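

In this assay compound 4 gives < 0.0667 h, which is a limit of the assay and not a number. At this saturated chain carbon, taking away the 4,5-dimethyl-1H-imidazol-2-yl does not by itself give a longer-lived compound: carbamoylmethyl shows an at least 1.2-fold lower number from compound 3 to compound 4 (0.08 log units; that floor lies within the scatter), a floor that leaves compound 3 and compound 4 without an order. The large gap to the (4H-1,2,4-triazol-3-yl)amino group now holds against two different replacements, with an at least 36-fold lower number from compound 2 to compound 4 (1.55 log units; beyond the scatter) beside the earlier 30-fold lower number from compound 2 to compound 3 (1.47 log units; beyond the scatter).

As far as these compounds go, how far compound 4 lies past the limit stays unknown: the limit of < 0.0667 h in this assay, at which 1 of the 4 values shown sits. Also open is whether the longer life of compound 2 follows the triazole ring or its amino link, which a plain amine or a carboxylic acid at this place could help to separate.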